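The compounds below may be only part of what the source reports. "The series", "measured", "known", "first", "only" and "open" are said of these compounds alone.

Of the compounds shown here, three of a shared family have been measured in a functional assay on SK-N-SH cells (Homo sapiens) for inhibition, read by MTT assay; a higher number here means a weaker inhibitor, a lower number a stronger inhibitor. Compound 1, with the structure `O=C(CN1CCC(Cc2ccccc2)CC1)Nc1ccc(C(=O)/C=C/c2cn(Cc3ccc(Br)cc3)nn2)cc1`, gives 42900 nM in this assay. Compound 3, `CCCCCCCCCCn1cc(/C=C/C(=O)c2ccc(NC(=O)CN3CCC(Cc4ccccc4)CC3)cc2)nn1`, differs from compound 1 by a single change, (nonyl in place of 4-bromophenyl on a saturated chain carbon bound to an aromatic nitrogen), and in this assay compound 3 gives 33300 nM. The step this change made is a 1.3-fold lower number from compound 1 to compound 3 (0.11 log units; within the scatter), so the two numbers cannot be told apart with confidence.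

Compound 2, `CC(C)(C)OC(=O)N1CCN(CC(=O)Nc2ccc(C(=O)/C=C/c3cn(Cc4ccc(Br)cc4)nn3)cc2)CC1`, carries a different core; the difference between the core of compound 2 and the core of compound 1 is not broken down here. In this assay compound 2 gives 25800 nM, which sits close to the other two values, so none of the three can be called stronger or weaker than the others.

Compound 4, `CCCCCCCCCCn1cc(/C=C/C(=O)c2ccc(NC(=O)CN3CCN(C(=O)OC(C)(C)C)CC3)cc2)nn1`, has not yet been measured. It is made from compound 2 by the same change that turned compound 1 into compound 3: nonyl in place of 4-bromophenyl on a saturated chain carbon bound to an aromatic nitrogen. The place of the change is described in identical words in both pairs, so this is the same change on a different core. Because the earlier step was a 1.3-fold lower number from compound 1 to compound 3 (0.11 log units; within the scatter), the expected step here is a 1.3-fold lower number from compound 2 to compound 4 (0.11 log units; within the scatter), resting on that single precedent alone. Compound 4 is therefore estimated to give about 20000 nM in this assay, with a plausible range from 8000 nM to 50000 nM.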

Compound 4, half-maximal inhibitory concentration: 77800 nM
Compound 4: middle estimate off by 3.9-fold (0.59 log units), on the low side; measured number above the stated range.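

In this assay, replacing 4-bromophenyl with nonyl on the core of compound 2 gives a 3.0-fold higher number from compound 2 to compound 4 (0.48 log units; beyond the scatter), a modest but real loss of strength. Set beside the earlier step, the same change clearly does not behave alike on the two cores: the same change on two cores in this assay, a 1.3-fold lower number (0.11 log units; within the scatter) from compound 1 to compound 3 and a 3.0-fold higher number (0.48 log units; beyond the scatter) from compound 2 to compound 4, 3.9-fold (0.59 log units) apart, beyond the scatter of two such steps

So, in these four compounds, the outcome of this change depends on the core that carries it, and a step measured on one core was a poor guide to the step on the other; but with only one pair per core, this does not show which feature of the cores is responsible, why the outcome differs, or how the change would behave on any further core.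

The compounds shown leave open which part of the core of compound 2 sets its step apart from the step on the core of compound 1, a question that cores differing from each other by a smaller edit could help to answer. They also leave open whether a shorter chain such as butyl, or a plain phenyl without the bromine, in the same place would behave like the nonyl group on both cores, and so whether the gap between the two steps holds beyond this one pair of groups.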